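The compounds below may be only part of what the source reports. "The series", "measured", "known", "first", "only" and "open" are said of these compounds alone.

Measured in a physicochemical assay for lipophilicity; on this read-out lower numbers stand for lower lipophilicity and higher numbers for higher lipophilicity:
compound 1 `CC1CCCN(Cc2c(-c3nnc(SC(C)C)n3-c3ccccc3)n(C)c3ccccc23)C1` gives 6.03
compound 2 `CC(C)Sc1nnc(-c2c(CNCC3CC3)c3ccccc3n2C)n1-c1ccccc1` gives 5.24
compound 3 `COc1ccc(CNCc2c(-c3nnc(SC(C)C)n3-c3ccccc3)n(C)c3ccccc23)cc1` gives 6.27

Compound 3 stands highest of the three numbers. Its nearest neighbour is compound 1, and the step of a number 0.24 log units higher from compound 1 to compound 3 (within the scatter) lies within the scatter, so the two cannot be ordered. Its furthest neighbour is compound 2, with the step of a number 1.03 log units higher from compound 2 to compound 3 (beyond the scatter) clearly beyond the scatter; the step of a number 0.79 log units lower from compound 1 to compound 2 (beyond the scatter) runs the other way between compounds 1 and 2.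

Compound 4 `COc1cccc(CNCc2c(-c3nnc(SC(C)C)n3-c3ccccc3)n(C)c3ccccc23)c1` differs from compound 3 by 3-methoxyphenyl in place of 4-methoxyphenyl on a saturated chain carbon bound to an amine nitrogen. Going by the values given here, none of the measured steps moves a methoxy group around a ring. Among the compounds with values here, the only step that touches this group, a number 1.03 log units higher from compound 2 to compound 3 (beyond the scatter), exchanges cyclopropyl for 4-methoxyphenyl and is large, but it says nothing about where the methoxy sits on the ring. Within the data shown here, with the atoms unchanged and no comparable step among the measured compounds, the expected step of no change at the digits printed from compound 3 to compound 4 (within the scatter) is none beyond the scatter. Compound 4 is therefore expected to give 6.27, estimated within 5.9 to 6.6.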

Compound 4, partition coefficient: 6.27
Compound 4: the middle estimate sits on the measured number at the digits printed; low and high end bracket the measured number.
By their numbers in this assay, from the lowest: compound 2; then compounds 1, 3 and 4 (each within the scatter of the next).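

In this assay, going by these compounds alone, replacing 4-methoxyphenyl with 3-methoxyphenyl on a saturated chain carbon bound to an amine nitrogen gives no change at the digits printed from compound 3 to compound 4 (within the scatter) and offers the first reading on where the methoxy sits on this ring. The large step away from cyclopropyl is seen with this ring too, at a number 1.03 log units higher from compound 2 to compound 4 (beyond the scatter), while a number 0.24 log units higher from compound 1 to compound 4 (within the scatter) leaves the (3-methoxybenzyl)amino compound unordered against the 3-methylpiperidin-1-yl compound, as the (4-methoxybenzyl)amino compound was. No supporting evidence bears on why the two methoxyphenyl groups read alike.

Still open, from the compounds shown here alone, is whether this reading would hold if a carboxylic acid or a dimethylamino group took the place of the methoxy on this ring. Also open, going by these compounds, is how a longer alkyl chain would read in place of the methoxyphenyl.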